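Cyclohexyl to 1-methylpiperidin-4-yl on the amine nitrogen

A few compounds are considered here, and "the series" means these few. Any claim that something is new, unique, unknown or untested is made for them only; others in the source may bear on it.

In a functional assay on NCI-H460 cells (Homo sapiens) for inhibition, read by sulforhodamine B assay, with a stated time of 72 h (on this read-out lower numbers stand for stronger inhibition and higher numbers for weaker inhibition), compound 1 `CCNC(=O)c1nnn(-c2cc(C(C)C)c(O)cc2O)c1-c1ccc(CN2CCCC2)cc1` gives 3 nM, compound 2 `CCNC(=O)c1nnn(-c2cc(C(C)C)c(O)cc2O)c1-c1ccc(CN2CCNCC2)cc1` gives 250 nM, and compound 3 `CCNC(=O)c1nnn(-c2cc(C(C)C)c(O)cc2O)c1-c1ccc(CNC2CCCCC2)cc1` gives 15 nM, the middle number of the three. Compound 4 `CCNC(=O)c1nnn(-c2cc(C(C)C)c(O)cc2O)c1-c1ccc(CNC2CCN(C)CC2)cc1` carries 1-methylpiperidin-4-yl in place of cyclohexyl on an amine nitrogen. For the measured compounds named here, no measured step makes this exact change. The closest guide is a 17-fold lower number from compound 2 to compound 3 (1.22 log units; beyond the scatter), a large step between piperazin-1-yl and cyclohexylamino. Also relevant are the large 83-fold higher number from compound 1 to compound 2 (1.92 log units; beyond the scatter) and the modest 5.0-fold higher number from compound 1 to compound 3 (0.70 log units; beyond the scatter). In this assay the expected change is a 3.0-fold higher number from compound 3 to compound 4 (0.48 log units; beyond the scatter), a rise beyond the scatter but smaller than those large steps. Compound 4 is estimated at 45 nM, with an expected range of 12 nM to 200 nM.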

Compound 4, half-maximal inhibitory concentration: > 1000 nM
Compound 4: only a limit was reported (the forecaster's own chance of this, stated with the estimate: 3%); at least 22-fold (1.34 log units) between middle value and limit.
By their numbers in this assay, from the lowest: compound 1; then compound 3; then compound 2. At a limit, above all of these: compound 4.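

Compound 4 reaches only a limit in this assay: the limit of > 1000 nM in this assay, at which 1 of the 4 values shown sits. On the amine nitrogen, a six-membered ring is tolerated as cyclohexyl but not as 1-methylpiperidin-4-yl, with an at least 66-fold higher number from compound 3 to compound 4 (1.82 log units; beyond the scatter). The two compounds with a second nitrogen in the amine part, compound 2 and compound 4, carry the two highest numbers, with an at least 4.0-fold higher number from compound 2 to compound 4 (0.60 log units; beyond the scatter), and the distance from the pyrrolidin-1-yl compound is wide, with an at least 330-fold higher number from compound 1 to compound 4 (2.52 log units; beyond the scatter).

Going by these compounds, whether the loss follows the ring nitrogen or its methyl stays open. Piperidin-4-yl without the methyl and tetrahydropyran-4-yl would separate the two.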